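The source may report more compounds than this note shows. Statements on the series, on what has been measured and on what is new or still open speak of the compounds shown alone.

Compound 1 `COc1ccc(/C(=C(/CCN)c2ccccc2)c2ccccc2)cc1` is the parent of this small set. In a functional assay on MCF7 cells (Homo sapiens) for cytotoxicity, read by MTT assay, with a stated time of 72 h (a higher number here means a weaker inhibitor, a lower number a stronger inhibitor), compound 1 gives 16900 nM, the lowest of the two numbers reported; compound 3 `COc1ccc(/C(=C(/CCNC(=O)NC2CCCCC2)c2ccccc2)c2ccccc2)cc1` gives 37200 nM, and compound 2 `COc1ccc(/C(=C(/CCNC(=O)Oc2ccccc2)c2ccccc2)c2ccccc2)cc1` is reported as "not active" (no number reported), with no number. Within the data shown here, the one measured step at this nitrogen is a 2.2-fold higher number from compound 1 to compound 3 (0.34 log units; beyond the scatter). Compound 4 `COc1ccc(/C(=C(/CCNC(=O)N2CCCC2)c2ccccc2)c2ccccc2)cc1` differs from compound 1 in the same place: (pyrrolidin-1-yl)carbonyl in place of hydrogen on an amine nitrogen. Among the measured compounds shown here, the single comparable step from compound 1 to compound 3 ran toward a higher number, and compound 2, the other substitution on this nitrogen, gave no activity at all, so for compound 4 a shift toward a higher number in this assay is expected, of a size like a 2.4-fold higher number from compound 1 to compound 4 (0.37 log units; beyond the scatter). Compound 4 is therefore estimated at 40000 nM, within a range of 18000 nM to 90000 nM.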

Compound 4, half-maximal inhibitory concentration: > 50000 nM
Compound 4: only a limit was reported (the forecaster's own chance of this, stated with the estimate: 25%); middle value at least 1.2-fold (0.09 log units) from the limit.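

In this assay compound 4 gives only a limit, > 50000 nM, not a number. Placing (pyrrolidin-1-yl)carbonyl on the amine nitrogen gives an at least 2.9-fold higher number from compound 1 to compound 4 (0.47 log units; beyond the scatter), making this the second measured step at this position to run toward a higher number. The change from cyclohexylamino to pyrrolidin-1-yl on the carbonyl carbon gives an at least 1.3-fold higher number from compound 3 to compound 4 (0.12 log units; that floor lies within the scatter), so this step does not separate the two groups.

The compounds shown leave open how far the number rises for compound 4. They also leave open whether a methyl or acetyl group on this nitrogen, or a longer chain carrying it, would keep the value of compound 1.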